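Swapping bromo for hydrogen on compound 1

A few compounds are considered here, and "the series" means these few. Any claim that something is new, unique, unknown or untested is made for them only; others in the source may bear on it.

Measured in a functional assay on SK-BR-3 cells (Homo sapiens) for cytotoxicity, read by MTT assay, with a stated time of 72 h; a lower number here means a stronger inhibitor, a higher number a weaker inhibitor:
compound 1 `NCCCNc1c(C(=O)NCc2ccc(F)cc2)nc(Br)c2cccnc12`: "not determined" (no result reported)
compound 2 `Nc1ccc(Nc2c(C(=O)NCc3ccc(F)cc3)nc(Br)c3cccnc23)cc1`: 4000 nM
compound 3 `CNCCCNc1c(C(=O)NCc2ccc(F)cc2)nc(Br)c2cccnc12`: 1000 nM

Compound 1 has no number, so this step has no measured starting point. Compound 4 `NCCCNc1c(C(=O)NCc2ccc(F)cc2)ncc2cccnc12` differs from compound 1 as follows: hydrogen in place of bromo on an aromatic carbon, which puts hydrogen in place of bromo on an aromatic carbon. Among the compounds with values here, the one measured step, a 4.0-fold lower number from compound 2 to compound 3 (0.60 log units; beyond the scatter), concerns another place, with 3-(methylamino)propyl in place of 4-aminophenyl, and both of its compounds keep the bromo. No measurement shows what removing bromo does in this assay, so the data point to no particular size or direction of step. The expectation can lean only on compound 3 at 1000 nM and compound 2 at 4000 nM, and its range is wide. For compound 4 the estimated value is 2000 nM, expected to fall between 400 nM and 10000 nM in most repeats.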

Compound 4, half-maximal inhibitory concentration: > 10000 nM
Compound 4 ended at the assay's limit (the forecaster's own chance of this, stated with the estimate: 8%); middle value at least 5.0-fold (0.69 log units) away from the limit.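

No step can be read from compound 1 to compound 4: compound 1 has no result, and compound 4 gives > 10000 nM, a limit of the assay and not a number. From the compounds shown here alone, what swapping bromo for hydrogen does here stays open, in both size and direction.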